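Oral Exposure After One Ring Swap in a Cyclic Dipeptide

A few compounds are considered here, and "the series" means these few. Any claim that something is new, unique, unknown or untested is made for them only; others in the source may bear on it.

Of the compounds shown here, two have so far been measured in an ADME assay on the whole organism (plasma) for pharmacokinetics, with Rattus norvegicus as the target, at a dose of 5 mg/kg by the oral route; on this read-out lower numbers stand for lower exposure and higher numbers for higher exposure at the dose given. Compound 1 `CC[C@H](C)[C@@H]1C(=O)N[C@H](C2Cc3ccccc3C2)C(=O)N1[C@@H](C(=O)N(C)C)c1ccc(C)[n+]([O-])c1` gives 24 ng.h/mL, the lowest of the two numbers. Compound 2 `CCC(CC)[C@@H]1C(=O)N[C@H](C2Cc3ccccc3C2)C(=O)N1[C@@H](C(=O)N1CCOCC1)c1ccc(C)nc1` differs from compound 1 in several places at once. In this assay compound 2 gives 1380 ng.h/mL, a much higher number, and this gap lies well beyond the usual scatter of repeated measurements. Compound 3 `CC[C@H](C)[C@@H]1C(=O)N[C@H](C2Cc3ccccc3C2)C(=O)N1[C@@H](C(=O)N(C)C)c1cnc(C)cc1C` has not yet been measured. It differs from compound 1 in a single place: a group of 8 heavy atoms (7 carbon, 1 nitrogen; one six-membered aromatic ring with 1 hetero atom) in place of a group of 8 heavy atoms (6 carbon, 1 nitrogen, 1 oxygen; one six-membered aromatic ring with 1 hetero atom), on a saturated chain carbon bound to an amide-type nitrogen in a ring and a carbonyl carbon. Among the compounds with values here, no step between measured compounds that differ in one place is available, so the forecast rests on the two values shown. A rise in exposure is expected from compound 1 to compound 3, of size a 10-fold higher number from compound 1 to compound 3 (1.02 log units; beyond the scatter), partly because compound 2 gives 1380 ng.h/mL while lacking the oxygen of the leaving group. Compound 3 is therefore estimated at 250 ng.h/mL, with a likely range from 40 ng.h/mL to 1500 ng.h/mL.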

Compound 3, area under the concentration-time curve: 2690 ng.h/mL
The estimate for compound 3 lay 11-fold (1.03 log units) below the measured number; the whole stated range lies below it.
By their numbers in this assay, from the lowest: compound 1; then compounds 2 and 3 (each within the scatter of the next).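

In this assay, exchanging only the aromatic group on the saturated chain carbon bound to an amide-type nitrogen in a ring and a carbonyl carbon gives a 110-fold higher number from compound 1 to compound 3 (2.05 log units; beyond the scatter), so a change at this one place, with the rest of the molecule held constant, can alter oral exposure far beyond the usual scatter. The two groups have the same number of heavy atoms, hydrogen-bond donors and acceptors and the same net charge, so these counts alone do not foretell the size of the step. No measurement on hand explains the rise.

This single pair cannot separate the loss of the oxygen from the addition of carbon in 4,6-dimethylpyridin-3-yl. On these data alone, how a phenyl or pyrimidine ring would behave at this carbon remains open.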